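This account rests on a few compounds, and the source may have more. Where it says the series, first, only, none or still open, it means among the compounds named here.

Of the compounds shown here, three sharing one core have been measured in an ADME assay for pharmacokinetics, read by LC-MS, in phosphate buffer, with a stated time of 72 h, at pH 7.4, tested at 250 uM; on this read-out higher numbers stand for a longer-lived compound and lower numbers for a shorter-lived compound. Compound 1 `C=CC(=O)Nc1cc(C(F)(F)F)cc(C(F)(F)F)c1` gives 5.7 h in this assay. For compound 2 `C=CC(=O)Oc1cc(C(F)(F)F)cc(C(F)(F)F)c1` the assay reports only a limit, < 0.017 h. For compound 3 `C=CS(=O)(=O)c1cc(C(F)(F)F)cc(C(F)(F)F)c1` it likewise reports only a limit, < 0.017 h. Compound 3 therefore sits at the limit of < 0.017 h in this assay, at which 2 of the 3 values shown sit, the floor of what this assay can report, and the step that the two limits leave unreadable from compound 2 to compound 3 cannot be read. Among the measured compounds shown here, the one readable step onto compound 3 is an at least 330-fold lower number from compound 1 to compound 3 (2.52 log units; beyond the scatter). Compound 4 `C=Cc1cc(C(F)(F)F)cc(C(F)(F)F)c1` differs from compound 3 by vinyl in place of vinylsulfonyl on an aromatic carbon. For the measured compounds named here, no measured step covers this change, and the size of an at least 330-fold lower number from compound 1 to compound 3 (2.52 log units; beyond the scatter) shows only that a large move away from the floor is possible. Compound 4 is therefore expected to give about 40 h in this assay, within 4 h to 300 h, which is expected to be a step of an at least 2300-fold higher number from compound 3 to compound 4 (3.37 log units; beyond the scatter).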

Compound 4, half-life: > 50 h
Compound 4 gave a limit, no number; the forecaster's own chance of this, stated with the estimate: 35%; at least 1.2-fold (0.09 log units) between middle value and limit.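

Compound 4 gives only a limit in this assay: the limit of > 50 h in this assay, at which 1 of the 4 values shown sits.

The earlier compounds shown here showed only losses from the amide, but this aromatic carbon can also carry a group that outlasts it, with an at least 8.7-fold higher number from compound 1 to compound 4 (0.94 log units; beyond the scatter). Bare vinyl is far longer-lived than either short-lived group it replaces, with an at least 2900-fold higher number from compound 3 to compound 4 (3.46 log units; beyond the scatter) and an at least 2900-fold higher number from compound 2 to compound 4 (3.46 log units; beyond the scatter).

Going by these compounds, the true half-life of compound 4 remains open. So does the behaviour of other groups in this place, such as an ethyl group, which lacks the double bond, or an amine.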